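This account rests on a few compounds, and the source may have more. Where it says the series, first, only, none or still open, it means among the compounds named here.

Compound 1 `Cc1ccc(S(=O)(=O)n2cc(-c3cc(C(F)(F)F)ccn3)c3ccccc32)cc1` is the smallest of three related compounds examined in a functional assay on A549 cells (Homo sapiens) for inhibition, tested at 10 uM (on this read-out lower numbers stand for a weaker effect and higher numbers for a stronger effect at the one concentration tested), and there compound 1 gives 35%, the highest of the three numbers, though neither of the others lies beyond the usual scatter from it. Compound 2 `COc1ccc2c(-c3cc(C(F)(F)F)cc(-c4cn(S(=O)(=O)c5ccc(C)cc5)c5cc(OC)ccc45)n3)cn(S(=O)(=O)c3ccc(C)cc3)c2c1` gives 28.8%, and compound 3 `Cc1ccc(S(=O)(=O)n2cc(-c3cc(C(F)(F)F)c(C#N)c(-c4cn(S(=O)(=O)c5ccc(C)cc5)c5cc(Br)ccc45)n3)c3ccc(Br)cc32)cc1` gives 27.6%, so the three cannot be told apart on these numbers. Compound 4 `Cc1ccc(S(=O)(=O)n2cc(-c3cc(C(F)(F)F)ccn3)c3cc(Br)ccc32)cc1` has not yet been measured. It differs from compound 1 in one place: bromo in place of hydrogen on an aromatic carbon. Going by the values given here, no measured pair shows this single change on its own, and compound 3, which also carries bromo, is too different in the rest of its structure to serve as a guide. The step is therefore expected to stay within the scatter, with no direction favoured. Compound 4 is expected to give about 33%, most likely between 18% and 48%. That expectation means a step of a number 2 percentage points lower from compound 1 to compound 4 (within the scatter).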

Compound 4, a percentage reported as inhibition, at one concentration (the size of the read-out at that concentration, not a potency): 20.6%
Beside the measured number, compound 4's estimate is 12.4 percentage points above it, within the range that was stated.
By their numbers in this assay, from the lowest: compounds 4, 3, 2 and 1 (each within the scatter of the next, the first and the last beyond it).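

Going by these compounds alone, putting bromo on this aromatic carbon, meta to a fused ring and para to a fused ring, is the first single change that can be read on its own, and in this assay it gives a number 14.4 percentage points lower from compound 1 to compound 4 (beyond the scatter). This position is therefore not indifferent: one added bromine atom is enough to lower the read-out. Nothing at hand explains the drop.

Going by these compounds, whether the fall is specific to bromo remains open, as a chloro group or an amine on the same carbon could show. Other positions on the shared core also remain unread.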